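Methoxy in place of bromo in the series

The compounds below may be only part of what the source reports. "The series", "measured", "known", "first", "only" and "open" are said of these compounds alone.

Going by the values given here, in a functional assay on CNE-2 cells (Homo sapiens) for antiproliferative activity, read by sulforhodamine B assay, with a stated time of 48 h (a higher number here means a weaker inhibitor, a lower number a stronger inhibitor), compound 1 (`COc1cc(C=C(C(=O)/C=C/c2cccc(OC)c2OC)C(=O)/C=C/c2cccc(OC)c2OC)ccc1O`) gives 280 nM and compound 2 (`COc1cc(C=C(C(=O)/C=C/c2cccc(OC)c2OC)C(=O)/C=C/c2cccc(OC)c2OC)cc(Br)c1O`) gives 220 nM, so compound 2 stands within the scatter of its only measured neighbour. Compound 3 (`COc1cc(C=C(C(=O)/C=C/c2cccc(OC)c2OC)C(=O)/C=C/c2cccc(OC)c2OC)cc(OC)c1O`) carries methoxy in place of bromo on an aromatic carbon, ortho to a hydroxy group: methoxy in place of bromo on an aromatic carbon. Among the compounds with values here, the only measured step at this place, bromo in place of hydrogen, is a 1.3-fold lower number from compound 1 to compound 2 (0.10 log units; within the scatter). No change beyond the scatter is therefore expected in this assay, in either direction. For compound 3 the expected value is 250 nM, with an estimated range of 110 nM to 550 nM. The estimated step is a 1.1-fold higher number from compound 2 to compound 3 (0.06 log units; within the scatter).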

Compound 3, half-maximal inhibitory concentration: 300 nM
Compound 3: the middle estimate sits 1.2-fold (0.08 log units) below what was measured; measured number inside the range.
By their numbers in this assay, from the lowest: compounds 2, 1 and 3 (each within the scatter of the next).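

In this assay, the place ortho to a hydroxy group now carries hydrogen, bromo or methoxy with no reading beyond the scatter: a 1.4-fold higher number from compound 2 to compound 3 (0.13 log units; within the scatter) for methoxy in place of bromo, and a 1.1-fold higher number from compound 1 to compound 3 (0.03 log units; within the scatter) for methoxy in place of hydrogen. The added hydrogen-bond acceptor of methoxy therefore separates neither from bromo nor from hydrogen in this assay. No evidence is available on what lies behind this flat reading.

Going by these compounds, whether an amine, a carboxylic acid or a longer alkoxy chain at this place would move the number beyond the scatter stays open.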